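Aryloxy in place of cyanobenzyl on the shared core

A few compounds are considered here, and "the series" means these few. Any claim that something is new, unique, unknown or untested is made for them only; others in the source may bear on it.

Compound 3 `COc1cccc(CNCCCNc2ccnc3cc(Cc4ccc(C#N)cc4)ccc23)c1O` gives 23 10^-6 cm/s in an ADME assay for permeability, using PAMPA, with a stated time of 30 min, at pH 7.4 (on this read-out lower numbers stand for lower permeability and higher numbers for higher permeability), level with compound 1 `COc1cccc(CNCCCNc2ccnc3cc(C4CCCCC4)ccc23)c1O`, which gives 23 10^-6 cm/s; together they are the lowest of the three numbers, while compound 2 `COc1cccc(CNCCCNc2ccnc3cc(-c4ccc(F)cc4)ccc23)c1O` gives 237 10^-6 cm/s. Compound 4 `COc1ccccc1Oc1ccc2c(NCCCNCc3cccc(OC)c3O)ccnc2c1` differs from compound 3 by 2-methoxyphenoxy in place of 4-cyanobenzyl on an aromatic carbon. For the measured compounds named here, two measured steps bear on this position: a 10-fold lower number from compound 2 to compound 3 (1.01 log units; beyond the scatter), and a 10-fold higher number from compound 1 to compound 2 (1.01 log units; beyond the scatter). Both were large, and both set an aromatic ring bonded directly to the core apart from the other two groups. Compound 4 carries such a ring through an oxygen, so its number is expected to rise, a 4.3-fold higher number from compound 3 to compound 4 (0.64 log units; beyond the scatter), though with a wide range. Compound 4 is therefore estimated at 100 10^-6 cm/s, between 30 10^-6 cm/s and 300 10^-6 cm/s.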

Compound 4, apparent permeability: 317 10^-6 cm/s
Compound 4: the middle estimate sits 3.2-fold (0.50 log units) below what was measured, and the stated range ends below it.
By their numbers in this assay, from the lowest: compounds 1 and 3 (each within the scatter of the next); then compounds 2 and 4 (each within the scatter of the next).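

At this position in this assay, 2-methoxyphenoxy and 4-fluorophenyl cannot be told apart, with a 1.3-fold higher number from compound 2 to compound 4 (0.13 log units; within the scatter). The other two groups stand clearly apart from 2-methoxyphenoxy, with a 14-fold higher number from compound 3 to compound 4 (1.14 log units; beyond the scatter) and a 14-fold higher number from compound 1 to compound 4 (1.14 log units; beyond the scatter), so among these four compounds an aromatic ring joined through oxygen matches one bonded directly, while the ring of 4-cyanobenzyl, joined through carbon, does not. Nothing given here explains these differences.

As far as these compounds go, whether the methoxy group on the phenoxy ring contributes remains open. So does how a plain phenoxy, a benzyloxy or a morpholine would read at this position.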